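Benzylamino versus aryloxy on the shared core

The source may hold more compounds than are shown below. What is called first, only, known or untested is meant among the compounds shown, and "the series" means these compounds.

Compound 1 `Nc1cc(N)c2nc(-c3ccccc3)c(Oc3ccc(Cl)c(Cl)c3)nc2c1` carries a 3,4-dichlorophenoxy group on the shared core. In a functional assay on NCI-H322M cells (Homo sapiens) for inhibition, read by sulforhodamine B assay, with a stated time of 48 h (a lower number here means a stronger inhibitor of growth, a higher number a weaker inhibitor of growth), compound 1 gives 21400 nM, the highest of the two numbers in hand. Compound 3 `COc1cc(CNc2nc3cc(N)cc(N)c3nc2-c2ccccc2)cc(OC)c1OC`, which carries a trimethoxybenzylamino group in place of that aryloxy group, gives 3020 nM in this assay, a lower number than that of compound 1 and a gap beyond the scatter. Compound 2 `CCOC(=O)[C@H](CCC(=O)O)NC(=O)c1ccc(CNc2nc3cc(N)cc(N)c3nc2-c2ccccc2)cc1` gives < 100000 nM in this assay, which is a limit of the assay and not a number.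

Compound 4 `Nc1cc(N)c2nc(-c3ccccc3)c(NCc3ccc(F)cc3)nc2c1` differs from compound 1 by (4-fluorobenzyl)amino in place of 3,4-dichlorophenoxy on an aromatic carbon, in words (4-fluorobenzyl)amino in place of 3,4-dichlorophenoxy on an aromatic carbon. For the measured compounds named here, no measured pair isolates exactly this change. Going by the values given here, the only benzylamino analogue with a number, compound 3 with 3020 nM, sits well below compound 1 with 21400 nM, so a move toward lower numbers, beyond the scatter, is expected for compound 4 as well, though the fluorobenzyl group need not match the trimethoxybenzyl group. The step expected here is a 4.3-fold lower number from compound 1 to compound 4 (0.63 log units; beyond the scatter). For compound 4 the estimate in this assay is 5000 nM, with a range from 1500 nM to 20000 nM.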

Compound 4, concentration for 50% growth inhibition: 3470 nM
For compound 4 the middle estimate is 1.4-fold (0.16 log units) above the measured one, and the stated range covers the measured number.
By their numbers in this assay, from the lowest: compounds 3 and 4 (each within the scatter of the next); then compound 1.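

In this assay, for the compounds shown here, the exchange at the aromatic carbon next to the ring nitrogen gives a 6.2-fold lower number from compound 1 to compound 4 (0.79 log units; beyond the scatter), the first direct reading of (4-fluorobenzyl)amino in place of 3,4-dichlorophenoxy on the shared core. Compound 3 with 3020 nM and compound 4 with 3470 nM lie within the scatter of each other, so the trimethoxybenzyl and 4-fluorobenzyl groups are not told apart in these numbers, and a second benzylamino compound now stands clearly lower than the aryloxy compound 1. The entering group brings a hydrogen-bond donor that the leaving group lacks, but nothing measured here gives a cause for the step.

The linking atom and the ring substituents change together in this step, so their shares stay unresolved; an unsubstituted benzylamino group, a 3,4-dichlorobenzylamino group or a longer chain such as phenethylamino would be needed to separate them. Compound 2 gives < 100000 nM, which is a limit of the assay and not a number, so it has no place in the order.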